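A few compounds are considered here, and "the series" means these few. Any claim that something is new, unique, unknown or untested is made for them only; others in the source may bear on it.

Compound 1 `Nc1nc(NCCNc2ncc(-c3ncc[nH]3)c(-c3ccc(Cl)cc3)n2)ccc1[N+](=O)[O-]`: > 0.5 h
Compound 2 `Nc1nc(NCCNc2ncc(-c3ncc[nH]3)c(-c3ccccc3Cl)n2)ccc1[N+](=O)[O-]`: > 0.5 h

In an ADME assay on microsomes from liver (Rattus norvegicus) for metabolic stability (a higher number here means that the compound lasts longer, a lower number that the compound disappears faster), compound 2 gives > 0.5 h, which is a limit and not a number. Compound 1 sits at the same limit, as the limit of > 0.5 h in this assay, at which 2 of the 2 values shown sit, shows. Among the measured compounds shown here, the only measured step, a step that the two limits leave unreadable from compound 1 to compound 2, therefore offers no size to carry over. Compound 3 `Nc1nc(NCCNc2ncc(-c3ncc[nH]3)c(-c3ccc(F)cc3F)n2)ccc1[N+](=O)[O-]` differs from compound 2 by 2,4-difluorophenyl in place of 2-chlorophenyl on an aromatic carbon. With no readable size to go on, no change beyond the scatter is expected, in either direction. The expected step is a step that the limit leaves unreadable from compound 2 to compound 3. Compound 3 is expected at 0.7 h, with an estimated range of 0.4 h to 1.5 h.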

Compound 3, half-life: > 0.5 h
Compound 3: a limit, no number (the forecaster's own chance of this, stated with the estimate: 75%); the middle value is on the limit's open side.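

No step among compound 1, compound 2 and compound 3 can be read, because all three give a limit and not a number: the limit of > 0.5 h in this assay, at which 3 of the 3 values shown sit.

On these data alone, the actual half-life of each compound, and whether exchanging these phenyl groups changes it, stays open.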